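The compounds below may be only part of what the source reports. "The series", "measured", "known", "first", "only" and "open" are said of these compounds alone.

Going by the values given here, in a functional assay on HCT-116 cells (Homo sapiens) for antiproliferative activity, read by MTT assay, with a stated time of 48 h (a lower number here means a stronger inhibitor, a higher number a weaker inhibitor), compound 2 `CCCCCCCC(CCO)n1cnc2c(Cl)ncnc21` gives 4160 nM, the only actual number available so far. Compound 1 `CCCCCCC(CCO)n1cnc2c(N)ncnc21` is reported at > 50000 nM, which is a limit of the assay and not a number. The next compound, compound 3 `CCCCCCCC(CCO)n1cnc2c(N)ncnc21`, keeps the chain of compound 2 and has amino in place of chloro on an aromatic carbon. Among the compounds with values here, no step between measured compounds is available to size this change directly. Compound 1 also carries the amino group, and its limit of > 50000 nM is the basis for expecting a step toward weaker inhibition in this assay, beyond the usual scatter. The estimated change a 7.2-fold higher number from compound 2 to compound 3 (0.86 log units; beyond the scatter) is therefore expected to be substantial. For compound 3 the expected value is 30000 nM, with an estimated range of 10000 nM to 90000 nM.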

Compound 3, half-maximal inhibitory concentration: > 50000 nM
Compound 3: no number, only a limit; the forecaster's own chance of this, stated with the estimate: 45%; middle value at least 1.6-fold (0.22 log units) away from the limit.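

In this assay compound 3 gives > 50000 nM, a limit of the assay and not a number. With the chain held the same, the swap of amino for chloro on this aromatic carbon can now be sized on its own, as an at least 12-fold higher number from compound 2 to compound 3 (1.07 log units; beyond the scatter), and of the two groups only chloro gives a measured number here. That size is only a lower bound: the limit of > 50000 nM in this assay, at which 2 of the 3 values shown sit.

On these data alone, the step between compound 1 and compound 3 cannot be read, both values being limits, so the effect of the chain with amino in place stays unknown. Also open, as far as these compounds go, is whether another group on this aromatic carbon, such as bromo, methoxy or methylamino, or a longer chain with chloro kept, would give a lower number than compound 2.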